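Aryl piperazine sulfonamides on a shared core: adenosine A3 binding

A few compounds are considered here, and "the series" means these few. Any claim that something is new, unique, unknown or untested is made for them only; others in the source may bear on it.

Values in an assay on CHO cells for displacement of a labelled ligand from adenosine receptor A3 (Homo sapiens), read by scintillation counting, with a stated time of 45 min, tested at 1 uM, in the presence of a further agent that is not named here; a lower number here means less inhibition, a higher number more inhibition at the concentration tested (going by the name of the read-out):
compound 1 `CCCn1c(=O)[nH]c2nc(-c3ccc(S(=O)(=O)N4CCN(c5ccccc5Br)CC4)cc3)[nH]c2c1=O` gives 20%
compound 2 `CCCn1c(=O)c2[nH]c(-c3ccc(S(=O)(=O)N4CCN(c5ccc(Cl)cc5)CC4)cc3)nc2n(C)c1=O` gives 39%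
compound 3 `CCCn1c(=O)[nH]c2nc(-c3ccc(S(=O)(=O)N4CCN(c5ccc(Br)cc5)CC4)cc3)[nH]c2c1=O` gives 29%

Compound 3 stands second highest of the three numbers. Its nearest neighbour is compound 1 and its furthest is compound 2, and both gaps lie within the scatter, so no order among the three can be read. Going by the values given here, the only step between compounds differing in one place is a number 9 percentage points higher from compound 1 to compound 3 (within the scatter), which puts 4-bromophenyl in place of 2-bromophenyl on an amine nitrogen in a ring and stays within the scatter. Compound 2 differs from compound 3 in more than one place; its value shows only a similar level of inhibition.

Compound 4 `CCCn1c(=O)[nH]c2nc(-c3ccc(S(=O)(=O)N4CCN(c5ccc(Cl)cc5F)CC4)cc3)[nH]c2c1=O` differs from compound 3 as follows: 4-chloro-2-fluorophenyl in place of 4-bromophenyl on an amine nitrogen in a ring. The step from compound 1 to compound 3 is the only one that bears on it, since it alters the same aryl group on the amine nitrogen in a ring, and it was within the scatter. Among the compounds with values here, no measured step tests a second halogen on that ring. For compound 4 in this assay the expected step is a number 1 percentage points higher from compound 3 to compound 4 (within the scatter), that is, no change beyond the scatter. Compound 4 is therefore estimated at 30%, with a range from 15% to 45%.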

Compound 4, a percentage reported as inhibition, at one concentration (the size of the read-out at that concentration, not a potency): 14%
Estimate against measurement, compound 4: 16 percentage points above, outside the stated range (below it).
By their numbers in this assay, from the lowest: compounds 4, 1, 3 and 2 (each within the scatter of the next, the first and the last beyond it).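

In this assay, going by these compounds alone, 4-chloro-2-fluorophenyl in place of 4-bromophenyl on an amine nitrogen in a ring gives a number 15 percentage points lower from compound 3 to compound 4 (beyond the scatter), the only step at this position that goes beyond the scatter, so the read-out does respond to the aryl group here, if modestly. The same group in place of 2-bromophenyl gives a number 6 percentage points lower from compound 1 to compound 4 (within the scatter), so the change registers only against 4-bromophenyl and not against 2-bromophenyl. Nothing available explains the step.

Which halogen carries the step stays open, as no pair shown changes the fluorine, the chlorine or the bromine alone. Every aryl group shown bears halogen, and how an unsubstituted phenyl or a methoxy group would read at this place also remains open.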